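Trading Two Chlorines for a Methoxy Group on Sulfur

A few compounds are considered here, and "the series" means these few. Any claim that something is new, unique, unknown or untested is made for them only; others in the source may bear on it.

The four compounds share one core, and the differences between them lie in the group attached to that core through a sulfur or an oxygen. Compound 1 `CCOC(=O)[C@H](CCC(=O)O)NC(=O)c1ccc(Sc2nc3cc(N)cc(N)c3nc2-c2ccccc2)cc1` carries the longest side chain of the set, and in a functional assay on SK-MEL-5 cells (Homo sapiens) for inhibition, read by sulforhodamine B assay, with a stated time of 48 h (on this read-out lower numbers stand for higher toxicity in this test and higher numbers for lower toxicity in this test), compound 1 gives 85100 nM. Compound 2 `Nc1cc(N)c2nc(-c3ccccc3)c(Oc3ccc(F)cc3)nc2c1` carries a 4-fluorophenoxy group, and in this assay compound 2 gives 83200 nM. Compound 3 `Nc1cc(N)c2nc(-c3ccccc3)c(Sc3ccc(Cl)c(Cl)c3)nc2c1` carries a (3,4-dichlorophenyl)sulfanyl group. For compound 3 the result in this assay is only a limit, < 100000 nM, not a number. Among the compounds with values here, for that reason the single measured step that leads to compound 3, a step that the limit leaves unreadable from compound 2 to compound 3, cannot be sized, since it rests on (the limit of < 100000 nM in this assay, at which 1 of the 3 values shown sits). The untested compound 4 `COc1ccc(Sc2nc3cc(N)cc(N)c3nc2-c2ccccc2)cc1` differs from compound 3 in one place: 4-methoxyphenyl in place of 3,4-dichlorophenyl on a sulfur. Within the data shown here, no measured step shows what this particular exchange does, so the expectation for compound 4 comes from where the measured numbers sit rather than from a direction; compound 1 at 85100 nM and compound 2 at 83200 nM lie within the usual scatter of each other. Compound 4 is therefore estimated at about 80000 nM, with a likely range from 35000 nM to 150000 nM.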

Compound 4, concentration lethal to 50% of the cells: < 100000 nM
Compound 4 gave a limit, no number; the forecaster's own chance of this, stated with the estimate: 35%; the middle value is on the limit's open side.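

In this assay compound 4 gives < 100000 nM as a limit, not a number. No new step can be read, either from compound 3 to compound 4 or from compound 2 to compound 4, because each rests on a limit: the limit of < 100000 nM in this assay, at which 2 of the 4 values shown sit. The compounds shown leave open whether 4-methoxyphenyl in place of 3,4-dichlorophenyl on a sulfur changes the toxicity in this test at all.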